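A few compounds are considered here, and "the series" means these few. Any claim that something is new, unique, unknown or untested is made for them only; others in the source may bear on it.

The three measured compounds share one core and differ only in the group on an aromatic nitrogen. Compound 1 is `CC(C)CCn1nc(C2CCCC2)c(O)c(C2=NS(=O)(=O)c3cc(NS(C)(=O)=O)ccc3N2)c1=O`, compound 2 is `CCCC(C)n1nc(-c2cccs2)c(O)c(C2=NS(=O)(=O)c3cc(NS(C)(=O)=O)ccc3N2)c1=O` and compound 3 is `CC(C)Cn1nc(-c2cccs2)c(O)c(C2=NS(=O)(=O)c3cc(NS(C)(=O)=O)ccc3N2)c1=O`. All three were tested in an ADME assay on Huh-7 cells (Homo sapiens) for cytotoxicity, with a stated time of 72 h; on this read-out lower numbers stand for higher toxicity in this test and higher numbers for lower toxicity in this test. Compound 1 gives > 1000 nM, which is a limit of this assay rather than a number. Compound 2 gives > 33000 nM, again a limit. Compound 3 gives > 1000 nM, also a limit. Compound 3 therefore stands at the limit of > 1000 nM in this assay, at which 2 of the 3 values shown sit, while one compound sits at the limit of > 33000 nM in this assay, at which 1 of the 3 values shown sits. Going by the values given here, the only single-point step among them, a step that the two limits leave unreadable from compound 2 to compound 3, cannot be read because both ends are limits.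

Compound 4 is `CS(=O)(=O)Nc1ccc2c(c1)S(=O)(=O)N=C(c1c(O)c(-c3cccs3)nn(Cc3ccc(F)cc3)c1=O)N2`, not yet measured in this assay. It differs from compound 3 by 4-fluorophenyl in place of isopropyl on a saturated chain carbon bound to an aromatic nitrogen.

No measured step offers a readable size, so the expectation rests on where the three compounds sit: none has shown toxicity within the tested range. Compound 4 is expected to behave alike, with the step that the limit leaves unreadable from compound 3 to compound 4 estimated to stay within the usual scatter and most likely unreadable once more. Compound 4 is thus estimated at 20000 nM, in a range from 3000 nM to 100000 nM, with a real chance that the assay again reports only a limit.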

Compound 4, half-maximal cytotoxic concentration: > 1000 nM
Compound 4 was reported as a limit; the forecaster's own chance of this, stated with the estimate: 70%; the middle value does not contradict the limit.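

In this assay compound 4 gives > 1000 nM, which is a limit and not a number. Compound 2 and compound 3 are also limits, so neither step to compound 4 can be read. The compounds shown leave open at what concentration each one harms the cells, and whether changing the group on the aromatic nitrogen matters.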